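Swapping Chloro for Amino on the Fused Core

A few compounds are considered here, and "the series" means these few. Any claim that something is new, unique, unknown or untested is made for them only; others in the source may bear on it.

Within the data shown here, compound 2 `Nc1nn(C(=O)Nc2ccc(Cc3ccccc3)cc2)c2ccc(Cl)cc12` gives 28200 nM in a functional assay on 786-0 cells (Homo sapiens) for antiproliferative activity, read by sulforhodamine B assay, with a stated time of 48 h; on this read-out lower numbers stand for stronger inhibition of growth and higher numbers for weaker inhibition of growth; this is the higher of the two numbers recorded, and its only neighbour, compound 1 `Nc1nn(C(=O)Nc2ccc(Cc3ccccc3)cc2)c2ccccc12`, gives 26200 nM. Among the measured compounds shown here, the one measured step, a 1.1-fold higher number from compound 1 to compound 2 (0.03 log units; within the scatter), stayed within the scatter. Compound 3 `Nc1ccc2c(c1)c(N)nn2C(=O)Nc1ccc(Cc2ccccc2)cc1` differs from compound 2 by amino in place of chloro on an aromatic carbon, at the same place where the chloro had been introduced. Because a 1.1-fold higher number from compound 1 to compound 2 (0.03 log units; within the scatter) lay within the scatter, no step beyond the scatter is expected here either. Compound 3 is expected to give about 25000 nM, between 10000 nM and 60000 nM. The expected step is a 1.1-fold lower number from compound 2 to compound 3 (0.05 log units; within the scatter).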

Compound 3, concentration for total growth inhibition: 25900 nM
The estimate for compound 3 lay 1.0-fold (0.02 log units) below the measured number; measured number inside the range.
By their numbers in this assay, from the lowest: compounds 3, 1 and 2 (each within the scatter of the next).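

With a 1.1-fold lower number from compound 2 to compound 3 (0.04 log units; within the scatter) and a 1.0-fold lower number from compound 1 to compound 3 (0.01 log units; within the scatter) in this assay, hydrogen, chloro and amino on this aromatic carbon cannot be told apart so far. Amino brings one hydrogen-bond donor and one hydrogen-bond acceptor where chloro has neither, yet the numbers of compound 2 and compound 3 stay within the scatter of each other. No evidence is available to explain this result. On these data alone, whether a carboxylic acid, a methoxy group or a longer chain on this carbon would behave the same remains open, as does whether changes elsewhere on the molecule would shift the number beyond the scatter.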